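The compounds below may be only part of what the source reports. "The series", "measured", "known", "first", "only" and "open" are said of these compounds alone.

Working notes on the series. Three compounds have numbers in an assay for inhibition of DNA topoisomerase 1 (Homo sapiens), with a stated time of 30 min, tested at 100 uM; on this read-out higher numbers stand for a stronger effect at the one concentration tested and lower numbers for a weaker effect. Compound 1 `O=C(/C=C/c1cccs1)c1ccccc1OCC1CO1` gives 11.1%. Compound 2 `O=C(/C=C/c1ccco1)c1cccc(OCC2CO2)c1` gives 28.5%. Compound 3 `O=C(/C=C/c1ccco1)c1ccc(OCC2CO2)cc1` gives 36.8%, the highest number shown; its gap to compound 2 lies within the scatter, so the two cannot be told apart on this assay, while its gap to compound 1 lies beyond the scatter. Among the compounds with values here, no two of the measured compounds differ in a single place, so no step has been computed among them.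

Compound 4 `O=C(/C=C/c1ccsc1)c1ccc(OCC2CO2)cc1` has not been measured in this assay. It differs from compound 3 as follows: thiophen-3-yl in place of furan-2-yl on a double-bonded chain carbon bound to a double-bonded chain carbon. Within the data shown here, nothing among the measured compounds isolates this exchange of one five-membered aromatic ring with one hetero atom for another. The step from compound 3 is therefore expected to be small, at most a slight fall, and in all likelihood no step beyond the scatter a number 6.8 percentage points lower from compound 3 to compound 4 (within the scatter). On that basis compound 4 is estimated to give 30%, between 10% and 55%.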

Compound 4, a percentage reported as inhibition, at one concentration (the size of the read-out at that concentration, not a potency): 46.3%
For compound 4 the middle estimate is 16.3 percentage points below the measured one; the measured number falls inside the stated range.
By their numbers in this assay, from the lowest: compound 1; then compounds 2, 3 and 4 (each within the scatter of the next, the first and the last beyond it).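

Within the data shown here, replacing furan-2-yl with thiophen-3-yl on a double-bonded chain carbon bound to a double-bonded chain carbon gives a number 9.5 percentage points higher from compound 3 to compound 4 (within the scatter) in this assay and is the first single-place exchange that can be read. At this place, the two five-membered aromatic rings cannot be told apart on this read-out, so the oxygen-containing ring is not required for the effect at the one concentration tested. No measurement shown here offers an explanation for this result.

As far as these compounds go, whether a larger or differently built group at this place, such as phenyl, pyridin-3-yl or a dimethylamino group, would preserve the read-out remains open. From the compounds shown here alone, it also remains open whether the same exchange would behave alike on the cores of compound 1 and compound 2.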